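The source may report more compounds than this note shows. Statements on the series, on what has been measured and on what is new or still open speak of the compounds shown alone.

In an ADME assay on L6 cells (Rattus norvegicus) for cytotoxicity, read by fluorescence, with a stated time of 72 h (on this read-out lower numbers stand for stronger inhibition and higher numbers for weaker inhibition), compound 1 (`CN1CCN(C23CC(NC(=O)CN4CCCC4)C(C(c4ccccc4)C2)C(c2ccccc2)C3)CC1`) gives 27800 nM. Among the compounds with values here, this is the lower of the two numbers measured so far, and compound 2 (`CCN(CC)CCCN1CCC2(N3CCN(C)CC3)CC(c3ccccc3)C1C(c1ccccc1)C2`) gives 68100 nM, a gap that lies beyond the usual scatter. Compound 1 therefore shows the stronger inhibition of the pair, though both numbers are high.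

The compound still to be measured, compound 3 (`CN1CCN(C23CC(NCCCN4CCCC4)C(C(c4ccccc4)C2)C(c2ccccc2)C3)CC1`), keeps the core of compound 1 and changes one place. It carries 3-(pyrrolidin-1-yl)propyl in place of ((pyrrolidin-1-yl)methyl)carbonyl on an amine nitrogen. The carbonyl is thus lost, while the pyrrolidine ring stays.

Within the data shown here, no measured pair isolates this change, and compound 2 differs from compound 1 in more than one place, so it cannot size the step. The expectation in this assay is therefore a loose one: a modest move towards stronger inhibition, possibly no larger than the scatter. The expected change is a 1.6-fold lower number from compound 1 to compound 3 (0.21 log units; within the scatter), and this remains an estimate. Compound 3 is expected to give 17000 nM, within an estimated range from 6000 nM to 48000 nM.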

Compound 3, half-maximal inhibitory concentration: 22600 nM
The estimate for compound 3 lay 1.3-fold (0.12 log units) below the measured number; low and high end bracket the measured number.
By their numbers in this assay, from the lowest: compounds 3 and 1 (each within the scatter of the next); then compound 2.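

In this assay, 3-(pyrrolidin-1-yl)propyl in place of ((pyrrolidin-1-yl)methyl)carbonyl on an amine nitrogen gives a 1.2-fold lower number from compound 1 to compound 3 (0.09 log units; within the scatter), the first step measured at this position. The carbonyl leaves with this exchange while the pyrrolidine ring and the count of heavy atoms in the group stay the same, and the two numbers remain within the scatter of each other, so in this assay the carbonyl of this group is shown to be dispensable, with no detectable effect on the number. Nothing measured on these compounds bears on why the two groups read alike.

The compounds shown leave open whether a shorter or longer chain leading to the pyrrolidine ring, or a piperidine or morpholine ring in its place, would also stay within the scatter of compound 1 and compound 3. They also leave open what a plain primary amine at this position, with neither chain attached, would give, and so how much of the group as a whole matters to the number in this assay.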